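Swapping sulfonamide for alcohol on the aromatic ring

The compounds below may be only part of what the source reports. "The series", "measured", "known", "first", "only" and "open" are said of these compounds alone.

Measured so far in an assay on CHO cells for displacement of a labelled ligand from Substance-P receptor (Homo sapiens), in the presence of a further agent that is not named here; on this read-out higher numbers stand for weaker inhibition and lower numbers for stronger inhibition:
compound 1 `C[C@@H](O[C@H]1CN2C(=O)C=C(c3ccccc3)CC2[C@@H]1c1ccc(F)cc1)c1cc(C(F)(F)F)cc(C(F)(F)F)c1` gives 89.5 nM
compound 2 `C[C@@H](O[C@H]1CN2C(=O)C=C(c3ccc(NS(C)(=O)=O)cc3)CC2[C@@H]1c1ccc(F)cc1)c1cc(C(F)(F)F)cc(C(F)(F)F)c1` gives 54 nM

Compound 2 sits at one end of the two numbers shown; its only neighbour is compound 1, and the step of a 1.7-fold lower number from compound 1 to compound 2 (0.22 log units; within the scatter) lies within the scatter. Compound 3 `C[C@@H](O[C@H]1CN2C(=O)C=C(c3ccc(CO)cc3)CC2[C@@H]1c1ccc(F)cc1)c1cc(C(F)(F)F)cc(C(F)(F)F)c1` differs from compound 2 in that (hydroxymethyl in place of methanesulfonamido on an aromatic carbon). For the measured compounds named here, the only step at this place, from compound 1 to compound 2, was small, and nothing measured shows how hydroxymethyl behaves there. Compound 3 is therefore expected to give a number close to compound 2, with a 1.3-fold higher number from compound 2 to compound 3 (0.11 log units; within the scatter) not beyond the scatter. Compound 3 is estimated at 70 nM in this assay, within 25 nM to 200 nM.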

Compound 3, half-maximal inhibitory concentration: 23 nM
Compound 3: middle estimate off by 3.0-fold (0.48 log units), on the high side; the whole stated range lies above it.
By their numbers in this assay, from the lowest: compound 3; then compounds 2 and 1 (each within the scatter of the next).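

At the aromatic carbon para to a large group, this assay now shows changes beyond the scatter: hydroxymethyl in place of methanesulfonamido gives a 2.3-fold lower number from compound 2 to compound 3 (0.37 log units; beyond the scatter), and hydroxymethyl in place of hydrogen gives a 3.9-fold lower number from compound 1 to compound 3 (0.59 log units; beyond the scatter). For the compounds shown here, the number at this position therefore depends on the group placed there, which the earlier compounds did not establish. Nothing available explains the difference.

On these data alone, whether the hydroxyl of hydroxymethyl matters remains open, and methoxymethyl would address that. Also open, as far as these compounds go, is how aminomethyl, a carboxylic acid or a longer hydroxyalkyl chain would behave here.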